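This account rests on a few compounds, and the source may have more. Where it says the series, first, only, none or still open, it means among the compounds named here.

Values in a functional assay on SK-MEL cells (Homo sapiens) for cytotoxicity, read by MTT assay, with a stated time of 6 days (on this read-out lower numbers stand for an effect already at smaller amounts and higher numbers for an effect only at larger amounts of compound), for the measured members of the series:

compound 1, `O=c1cc(-c2ccc([N+](=O)[O-])cc2)oc2ccc(O)cc12`: 21 ug/mL
compound 2, `O=c1cc(-c2ccc([N+](=O)[O-])cc2)oc2cc(O)ccc12`: > 25 ug/mL, which is a limit of the assay and not a number
compound 3, `Nc1ccc(-c2cc(=O)c3cc(O)ccc3o2)cc1`: 2.03 ug/mL

Compound 1 and compound 2 are built from the same atoms joined differently; the difference between the two cores is not broken down here. Compound 2 sits at the limit of > 25 ug/mL in this assay, at which 1 of the 3 values shown sits, so only a limit is known for it. Among the measured compounds shown here, the one measured step is a 10-fold lower number from compound 1 to compound 3 (1.01 log units; beyond the scatter); the change behind it is amino in place of nitro on an aromatic carbon.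

Compound 4, `Nc1ccc(-c2cc(=O)c3ccc(O)cc3o2)cc1`, has not been measured in this assay. It carries the same change on the core of compound 2: amino in place of nitro on an aromatic carbon. The place is described in the same words as for the step from compound 1 to compound 3, so this is the same change on the other core.

For compound 4 the step expected is an at least 5.0-fold lower number from compound 2 to compound 4 (0.69 log units; beyond the scatter), resting on a 10-fold lower number from compound 1 to compound 3 (1.01 log units; beyond the scatter), with the caution that compound 2 gives only a limit as the starting point. The estimate for compound 4 is 5 ug/mL, within 1.5 ug/mL to 20 ug/mL.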

Compound 4, concentration for half-maximal effect: 6.59 ug/mL
Compound 4: middle estimate off by 1.3-fold (0.12 log units), on the low side; the measured number falls inside the stated range.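

In this assay, amino in place of nitro on an aromatic carbon gives an at least 3.7-fold lower number from compound 2 to compound 4 (0.57 log units; beyond the scatter), the same direction as a 10-fold lower number from compound 1 to compound 3 (1.01 log units; beyond the scatter). Set side by side, the two steps read: the same change on two cores in this assay, a 10-fold lower number (1.01 log units; beyond the scatter) from compound 1 to compound 3 and an at least 3.7-fold lower number (0.57 log units; beyond the scatter) from compound 2 to compound 4; the limit leaves it open whether they differ. Compound 2 gives > 25 ug/mL, which is a limit of the assay and not a number, so the size of the change on this core stays unfixed; the two pairs show that the direction carries from one core to the other, not that the size does.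

The compounds shown leave open whether a group other than amino, such as a dimethylamino group or an acetamide, in the same place para to a large group would move the number in the same way on both cores. They also leave open how far the two steps would lie apart if compound 2 had a number instead of a limit, and whether the direction holds on any core beyond these two.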